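From thiophen-3-yl to pyridin-2-yl in the series

This account rests on a few compounds, and the source may have more. Where it says the series, first, only, none or still open, it means among the compounds named here.

- Compound 1 `COc1ccc(C(=O)/C=C/c2ccc(F)cc2)c2c1C=CC(C)(C)O2` gives > 10000 nM (a limit)
- Compound 2 `COc1ccc(C(=O)/C=C/c2ccc(N(C)C)cc2)c2c1C=CC(C)(C)O2` gives 730 nM
- Compound 3 `COc1ccc(C(=O)/C=C/c2ccsc2)c2c1C=CC(C)(C)O2` gives > 10000 nM (a limit)

All three were read in a functional assay on HepG2 cells (Homo sapiens) for antiproliferative activity, read by MTT assay, with a stated time of 24 h; on this read-out lower numbers stand for stronger inhibition and higher numbers for weaker inhibition. Compound 3 stands at > 10000 nM, which is a limit of the assay and not a number.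

The next change gives compound 4 `COc1ccc(C(=O)/C=C/c2ccccn2)c2c1C=CC(C)(C)O2`, with pyridin-2-yl in place of thiophen-3-yl on a double-bonded chain carbon bound to a double-bonded chain carbon.

Among the measured compounds shown here, three measured steps bear on it. Two are large: an at least 13-fold lower number from compound 1 to compound 2 (1.13 log units; beyond the scatter) and an at least 13-fold higher number from compound 2 to compound 3 (1.13 log units; beyond the scatter). For the measured compounds named here, both involve compound 2, the only compound with a dimethylamino group and the only one with a numerical value. The third cannot be sized: a step that the two limits leave unreadable from compound 1 to compound 3. Compound 4 has no dimethylamino group, so no large step is expected in this assay, and a reading may again stop at the limit of > 10000 nM in this assay, at which 2 of the 3 values shown sit. The expected step is an at least 1.1-fold lower number from compound 3 to compound 4 (0.04 log units; that floor lies within the scatter). The estimated value for compound 4 is 9000 nM, with an expected range from 3000 nM to 20000 nM.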

Compound 4, half-maximal inhibitory concentration: 5760 nM
The estimate for compound 4 lay 1.6-fold (0.19 log units) above the measured number; measured number inside the range.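

In this assay, among the compounds shown here, compound 4 is the first compound without a dimethylamino group to give a number and not a limit, which places the pyridin-2-yl ring on the measurable scale at this double-bonded chain carbon. Against the limits, the change reads as an at least 1.7-fold lower number from compound 3 to compound 4 (0.23 log units; that floor lies within the scatter) and as an at least 1.7-fold lower number from compound 1 to compound 4 (0.23 log units; that floor lies within the scatter). Against the one other number, it reads as a 7.9-fold higher number from compound 2 to compound 4 (0.90 log units; beyond the scatter), so 4-(dimethylamino)phenyl keeps a clear lead over pyridin-2-yl at this place.

Compound 1 and compound 3 remain limits and not numbers, so these two steps give floors and no true sizes: the limit of > 10000 nM in this assay, at which 2 of the 4 values shown sit.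

Open, on these data alone, is whether the lead of compound 2 belongs to the dimethylamino group or to the phenyl ring that carries it. A pyridin-2-yl ring bearing dimethylamino, or a phenyl ring bearing morpholine, would help separate the two.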